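This account rests on a few compounds, and the source may have more. Where it says the series, first, only, none or still open, it means among the compounds named here.

Measured in a functional assay on SK-OV-3 cells (Homo sapiens) for antiproliferative activity, read by MTT assay, with a stated time of 72 h; on this read-out lower numbers stand for stronger inhibition and higher numbers for weaker inhibition:
- compound 1 `Cc1cc(C)c(NC(=O)CCc2cccc3c2B(O)OC3)c(C)c1`: 19000 nM
- compound 2 `CC(=O)c1ccc(-c2cccc(NC(=O)CCc3cccc4c3COB4O)c2)cc1`: 57000 nM
- compound 3 `CC(=O)c1ccc(-c2cccc(NC(=O)CCc3ccccc3)c2)cc1`: 3200 nM

Compound 3, at 3200 nM, has the lowest number of the three. Compound 4 `CC(=O)c1ccc(-c2cccc(NC(=O)CCc3cccc4c3C(O)OC4)c2)cc1` has not yet been measured and carries a group of 10 heavy atoms (8 carbon, 2 oxygen; one five-membered non-aromatic ring with 1 hetero atom, one six-membered aromatic ring of carbon only) in place of a group of 6 heavy atoms (6 carbon; one six-membered aromatic ring of carbon only), on a saturated chain carbon, two bonds along the chain from a carbonyl carbon. Within the data shown here, one measured step bears on this change: an 18-fold lower number from compound 2 to compound 3 (1.25 log units; beyond the scatter), where phenyl replaced a two-ring group containing boron. Among the measured compounds shown here, compound 4 reverses that kind of exchange, but its entering group has no boron, and no measured compound carries that group. A higher number is therefore expected in this assay, probably a large step, though somewhat smaller than the measured one. The expected step is a 5.6-fold higher number from compound 3 to compound 4 (0.75 log units; beyond the scatter). The estimate for compound 4 is 18000 nM, with an expected range of 6000 nM to 55000 nM.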

Compound 4, half-maximal inhibitory concentration: 41000 nM
The estimate for compound 4 lay 2.3-fold (0.36 log units) below the measured number, and the stated range covers the measured number.
By their numbers in this assay, from the lowest: compound 3; then compound 1; then compounds 4 and 2 (each within the scatter of the next).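

In this assay, the boron-free two-ring group on the saturated chain carbon also goes with a large change, a 13-fold higher number from compound 3 to compound 4 (1.11 log units; beyond the scatter), so among these compounds the higher number does not depend on boron. Exchanging the boron-containing group for this boron-free one gives a change within the scatter, a 1.4-fold lower number from compound 2 to compound 4 (0.14 log units; within the scatter), and the two groups cannot be told apart here. Nothing available explains this result. As far as these compounds go, it remains open whether a phenyl carrying a single methoxy or carboxylic acid, or a longer chain, would keep the number of compound 3.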